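Swapping the aromatic ring on a piperazine-type nitrogen

The source may hold more compounds than are shown below. What is called first, only, known or untested is meant among the compounds shown, and "the series" means these compounds.

Three compounds sharing one core were tested in a functional assay on MGC-803 cells (Homo sapiens) for antiproliferative activity, read by CCK-8 assay, with a stated time of 72 h, tested at 8 uM; a higher number here means a stronger effect of the compound at the concentration tested, a lower number a weaker effect. Compound 1 `Nc1ccccc1NC(=O)c1ccc(CSC(=S)N2CCc3ccc([N+](=O)[O-])cc32)cc1` gives 39.6%. Compound 2 `CN(Cc1cccnc1)C(=S)SCc1ccc(C(=O)Nc2ccccc2N)cc1` gives 85.5%. Compound 3 `Nc1ccccc1NC(=O)c1ccc(CSC(=S)N2CCN(c3ccncc3)CC2)cc1` gives 87.1%, the highest of the three numbers, though its gap to compound 2 lies within the usual scatter of such measurements, and only compound 1 stands clearly lower. Compound 4 `Nc1ccccc1NC(=O)c1ccc(CSC(=S)N2CCN(c3ncccn3)CC2)cc1` is the next step. Its change from compound 3 is pyrimidin-2-yl in place of pyridin-4-yl on an amine nitrogen in a ring: a six-membered aromatic ring with two hetero atoms replaces one with a single hetero atom, a group of the same size in the same place. Among the compounds with values here, no measured pair shows what such a swap does here, so the expected step stays within the scatter, with no clear direction. For compound 4 the expected result in this assay is 82%, ranging from 65% to 93%. The step expected from this change, a number 5.1 percentage points lower from compound 3 to compound 4 (within the scatter), is small.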

Compound 4, a percentage reported as inhibition, at one concentration (the size of the read-out at that concentration, not a potency): 64.8%
Compound 4: the middle estimate sits 17.2 percentage points above what was measured; the whole stated range lies above it.
By their numbers in this assay, from the lowest: compound 1; then compound 4; then compounds 2 and 3 (each within the scatter of the next).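

In this assay this place on the piperazine-type amine nitrogen proves sensitive to which aromatic ring it carries: pyrimidin-2-yl in place of pyridin-4-yl gives a number 22.3 percentage points lower from compound 3 to compound 4 (beyond the scatter) even though both rings have the same count of heavy atoms. Matching size therefore does not guarantee a matching result in this series. No measurement shown here explains this difference.

Within the data shown here, with only one pair, it remains open whether the number of ring nitrogens or their location matters more. A phenyl ring or pyridin-2-yl on the same nitrogen would help separate the two.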